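Three Aryloxy Ketones at the Limit, and a Trifluorophenyl Fourth

The compounds below may be only part of what the source reports. "The series", "measured", "known", "first", "only" and "open" are said of these compounds alone.

Compound 3 `CC(C)[C@H](NC(=O)COc1cccc2ccccc12)C(=O)N[C@@H](CC(=O)O)C(=O)COc1ccc(F)cc1` was tested in a functional assay on Jurkat cells (Homo sapiens); on this read-out lower numbers stand for stronger inhibition and higher numbers for weaker inhibition. In this assay compound 3 reaches only the limit of > 100000 nM, which is a limit of the assay and not a number. Compound 1 `CC(C)[C@H](NC(=O)COc1cccc2ccccc12)C(=O)N[C@@H](CC(=O)O)C(=O)COc1cccc2ccccc12` likewise stops at the limit of > 100000 nM. Compound 2 `CC(C)[C@H](NC(=O)COc1cccc2ccccc12)C(=O)N[C@@H](CC(=O)O)C(=O)COc1ccc([N+](=O)[O-])cc1` also stops at the limit of > 100000 nM. Compound 3 thus stands exactly where the other two measured compounds stand: the limit of > 100000 nM in this assay, at which 3 of the 3 values shown sit. The steps among them, a step that the two limits leave unreadable from compound 1 to compound 2, a step that the two limits leave unreadable from compound 1 to compound 3 and a step that the two limits leave unreadable from compound 2 to compound 3, cannot be given a size, so they say nothing about how exchanging the aryl group on the oxygen matters in this assay.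

Compound 4 `CC(C)[C@H](NC(=O)COc1cccc2ccccc12)C(=O)N[C@@H](CC(=O)O)C(=O)COc1c(F)cc(F)cc1F` differs from compound 3 by 2,4,6-trifluorophenyl in place of 4-fluorophenyl on an oxygen on a saturated carbon. Going by the values given here, no measured step bears on this change in a readable way, and every measured compound sits at the same limit. The expectation for compound 4 is a value of 100000 nM, within a range from 20000 nM to 500000 nM, and most probably again reported only as a limit. That estimate means an expected step of a number no higher from compound 3 to compound 4 (the limit leaves the size open), which is no change beyond the scatter.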

Compound 4, half-maximal inhibitory concentration: 6840 nM
For compound 4 the middle estimate is 15-fold (1.16 log units) above the measured one, outside the stated range (below it).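

With 2,4,6-trifluorophenyl on the oxygen, the shared core at last gives a measurable number in this assay, which shows that this position responds to the aryl group placed there. Against 4-fluorophenyl the change is an at least 14-fold lower number from compound 3 to compound 4 (1.16 log units; beyond the scatter), and against the other two aryl groups it is an at least 14-fold lower number from compound 2 to compound 4 (1.16 log units; beyond the scatter) and an at least 14-fold lower number from compound 1 to compound 4 (1.16 log units; beyond the scatter). The steps among the three earlier compounds still cannot be read, and only one value stands clear of the limit: the limit of > 100000 nM in this assay, at which 3 of the 4 values shown sit.

The compounds shown leave open whether a 2,4-difluorophenyl or a 2,6-difluorophenyl group would give a similar step, so it cannot be told which of the added fluorines matter. Also open, from the compounds shown here alone, is whether a 2,4,6-trichlorophenyl group on the same oxygen would lower the number further or lose the gain.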